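A few compounds are considered here, and "the series" means these few. Any claim that something is new, unique, unknown or untested is made for them only; others in the source may bear on it.

Working notes on the series in a functional assay on ileum for inhibition of histamine H1 receptor (Cavia porcellus); on this read-out higher numbers stand for weaker inhibition and lower numbers for stronger inhibition.

For the measured compounds named here, compound 1 `CCNCCn1c(N2CCN(C)CC2)nc2ccccc21` gives 290 nM, the highest of the three numbers measured so far. Compound 2 `C=CCOCCn1c(N2CCCN(C)CC2)nc2ccccc21` gives 10 nM and compound 3 `CN1CCCN(c2nc3ccccc3n2CCOc2ccccc2)CC1` gives 9.1 nM; the step of a 1.1-fold lower number from compound 2 to compound 3 (0.04 log units; within the scatter) shows that exchanging the group on the oxygen makes no difference that stands out of the scatter. Going by the values given here, compounds 2 and 3 differ from compound 1 in more than one place, so no single measured step leads away from compound 1.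

Compound 4 `CN1CCN(c2nc3ccccc3n2-c2ccccc2)CC1` is not yet measured. It differs from compound 1 by phenyl in place of 2-(ethylamino)ethyl on an aromatic nitrogen. Among the compounds with values here, no measured step touches the substituent on the aromatic nitrogen of the shared core, and the only measured step concerns an oxygen on a saturated carbon, so nothing in the data sets the size or direction of this change. The two more potent compounds carry no basic chain on the aromatic nitrogen, which speaks weakly against the chain being required, but they also differ elsewhere. Compound 4 is therefore expected to land near compound 1 with a modest improvement, the expected step being a 2.9-fold lower number from compound 1 to compound 4 (0.46 log units; beyond the scatter). Compound 4 is estimated at 100 nM, within a range from 20 nM to 600 nM.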

Compound 4, half-maximal inhibitory concentration: 760 nM
Beside the measured number, compound 4's estimate is 7.6-fold (0.88 log units) below it; the whole stated range lies below it.
By their numbers in this assay, from the lowest: compounds 3 and 2 (each within the scatter of the next); then compound 1; then compound 4.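

In this assay, the substituent on the aromatic nitrogen of the shared core now has its first measured step: a 2.6-fold higher number from compound 1 to compound 4 (0.42 log units; beyond the scatter), with phenyl in place of 2-(ethylamino)ethyl. The position therefore responds to this exchange, but only modestly: the open chain with its hydrogen-bond donor and acceptor gives way to an all-carbon aromatic ring with neither, and compound 4 still gives 760 nM. No supporting measurement assigns this shift to any particular feature of the exchange.

For the compounds shown here, the single step removes the chain nitrogen and introduces the aromatic ring together, leaving the contribution of each change open. A plain ethyl group, a benzyl group, a 2-phenylethyl chain or a 2-(dimethylamino)ethyl chain on the same aromatic nitrogen would help separate these contributions, and a phenyl group combined with a basic amine would show whether the two can work together.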